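This account rests on a few compounds, and the source may have more. Where it says the series, first, only, none or still open, it means among the compounds named here.

Series notes. Compound 1 `COC(=O)[C@@]1(C)CC[C@@H]2C3=C1CC[C@@H](C)[C@]3(C)C[C@@H]1c3ccccc3N[C@H]21` gives 50000 nM in a functional assay on WiDr cells (Homo sapiens) for inhibition, read by sulforhodamine B assay, with a stated time of 48 h; on this read-out lower numbers stand for stronger inhibition of growth and higher numbers for weaker inhibition of growth. Compound 2 `COC(=O)[C@@]1(C)CC[C@@H]2C3=C1CC[C@@H](C)[C@]3(C)C[C@@H]1c3cccc(C)c3N[C@H]21`, with methyl in place of hydrogen on an aromatic carbon, gives 43000 nM in this assay; compound 3 `COC(=O)[C@@]1(C)CC[C@@H]2C3=C1CC[C@@H](C)[C@]3(C)C[C@@H]1c3cccc(Br)c3N[C@H]21`, with bromo at that carbon, gives 54000 nM in this assay. Compound 3 does not separate from either neighbour: a 1.1-fold higher number from compound 1 to compound 3 (0.03 log units; within the scatter) and a 1.3-fold higher number from compound 2 to compound 3 (0.10 log units; within the scatter). Compound 4 `COC(=O)[C@@]1(C)CC[C@@H]2C3=C1CC[C@@H](C)[C@]3(C)C[C@@H]1c3cccc(Cl)c3N[C@H]21` carries chloro in place of bromo on an aromatic carbon. The step that bears on this is the bromo-for-hydrogen change a 1.1-fold higher number from compound 1 to compound 3 (0.03 log units; within the scatter), and the methyl change a 1.2-fold lower number from compound 1 to compound 2 (0.07 log units; within the scatter) is equally flat; no substituent tried at this carbon has moved the number. For compound 4 the expected step is therefore a 1.1-fold lower number from compound 3 to compound 4 (0.03 log units; within the scatter), nothing beyond the scatter. The estimate for compound 4 in this assay is 50000 nM, range 30000 nM to 85000 nM.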

Compound 4, concentration for 50% growth inhibition: 67000 nM
The estimate for compound 4 lay 1.3-fold (0.13 log units) below the measured number; the measured number falls inside the stated range.
By their numbers in this assay, from the lowest: compounds 2, 1, 3 and 4 (each within the scatter of the next).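

In this assay chloro, a second halogen at this carbon, also leaves the number flat: a 1.2-fold higher number from compound 3 to compound 4 (0.09 log units; within the scatter) stands with a 1.3-fold higher number from compound 1 to compound 4 (0.13 log units; within the scatter) and a 1.6-fold higher number from compound 2 to compound 4 (0.19 log units; within the scatter) as steps inside the scatter. Hydrogen, methyl, bromo and chloro at this carbon therefore do not separate from one another on this read-out. No data at hand bear on this flatness.

From the compounds shown here alone, whether an amine, a hydroxyl or a carboxylic acid at this carbon would move the number remains open. So does whether a change elsewhere on the shared core, such as at the ester, would do so.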